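Methyl for hydrogen on the nitrogen-bound chain, second instance

The compounds below may be only part of what the source reports. "The series", "measured", "known", "first", "only" and "open" are said of these compounds alone.

Compound 1 `CSc1nnc(-c2ccc(Cl)cc2)n1C` and compound 2 `CCn1c(SC)nnc1-c1ccc(Cl)cc1` differ by methyl in place of hydrogen on a saturated chain carbon bound to an aromatic nitrogen. In a functional assay on the whole organism for antagonist activity, with Mus musculus as the target (a lower number here means that less compound is needed, a higher number that more compound is needed for the effect), compound 1 gives 28.1 mg/kg and compound 2 gives 26.7 mg/kg, and the step is a 1.1-fold lower number from compound 1 to compound 2 (0.02 log units; within the scatter), so the two numbers cannot be told apart.

Compound 3 `CSc1nnc(-c2ccccc2F)n1C` differs from compound 1 in more than one place; the difference between the two cores is not broken down here. In this assay compound 3 gives 8.8 mg/kg, the lowest of the three numbers, and its gaps to compound 2 and to compound 1 are both beyond the scatter.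

Compound 4 `CCn1c(SC)nnc1-c1ccccc1F` is not yet measured. Going by the values given here, it differs from compound 3 by methyl in place of hydrogen on a saturated chain carbon bound to an aromatic nitrogen, which is the same change, at the same place, as the one separating compound 1 from compound 2. Among the compounds with values here, the only measured instance of that change is the one above, where the number moved within the scatter. Within the data shown here, the expectation for compound 4 rests on that single instance and on nothing else, since no second pair of this kind is measured.

In this assay the estimated step is a 1.0-fold lower number from compound 3 to compound 4 (0.02 log units; within the scatter), expected to stay small because a 1.1-fold lower number from compound 1 to compound 2 (0.02 log units; within the scatter). Compound 4 is therefore expected to give 8.5 mg/kg in this assay, with an estimated range from 4.5 mg/kg to 16 mg/kg.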

Compound 4, dose for half-maximal effect: 75 mg/kg
Beside the measured number, compound 4's estimate is 8.8-fold (0.95 log units) below it; measured number outside the range, above it.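

In this assay, methyl in place of hydrogen on a saturated chain carbon bound to an aromatic nitrogen gives an 8.5-fold higher number from compound 3 to compound 4 (0.93 log units; beyond the scatter), so on the core of compound 3 this methyl to ethyl change means that more compound is needed, which the core of compound 1 does not show. The change therefore does not carry from one core to the other in this series, and the two instances disagree: the same change on two cores in this assay, a 1.1-fold lower number (0.02 log units; within the scatter) from compound 1 to compound 2 and an 8.5-fold higher number (0.93 log units; beyond the scatter) from compound 3 to compound 4, 9.0-fold (0.95 log units) apart, beyond the scatter of two such steps. Not shown is which difference between the cores goes with this disagreement: compound 1 and compound 3 differ in more than one place, and two pairs set no rule for a third core.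

Open, going by these compounds, is whether a longer chain, such as propyl or butyl, in the place of the ethyl continues the upward move on the core of compound 3, and whether the core of compound 1 stays unmoved with the same chains. Also open, on these data alone, is how a chain ending in a hydroxyl or an amine would read on each of the two cores, and whether such a group would keep the two cores apart as methyl does.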